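Smaller Lactam Ring Substituent: Solubility Expectation for Compound 4

This account rests on a few compounds, and the source may have more. Where it says the series, first, only, none or still open, it means among the compounds named here.

Measured compounds:
compound 1, `Cc1ncccc1-c1cnc(NCc2c(F)ccc3c2CCO3)c2ncc(=O)[nH]c12`: 29000 nM
compound 2, `CC1(C)CC(=O)N(c2cnc(NCc3c(F)ccc4c3CCO4)n3cnnc23)C1`: 57000 nM
compound 3, `CNC(=O)c1ncc(-c2cnc(NCc3c(F)ccc4c3CCO4)c3cn[nH]c(=O)c23)n1C`: 5000 nM

Of the compounds shown here, three have been measured in a physicochemical assay for solubility, read by LC-MS, in phosphate buffer, with a stated time of 24 h, at pH 7.4; on this read-out higher numbers stand for higher solubility and lower numbers for lower solubility. Compound 2 stands highest of the three numbers, giving 57000 nM. Its nearest neighbour is compound 1, which gives 29000 nM, a gap that lies within the usual scatter of the measurement, so no order between compound 1 and compound 2 can be claimed. Compound 3, with 5000 nM, stands furthest from compound 2, and that gap lies beyond the scatter.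

Compound 4, `O=C1CCCN1c1cnc(NCc2c(F)ccc3c2CCO3)n2cnnc12`, has not yet been measured in this assay. It differs from compound 2 in one place: 2-oxopyrrolidin-1-yl in place of 4,4-dimethyl-2-oxopyrrolidin-1-yl on an aromatic carbon. For the measured compounds named here, no step between measured compounds that matches this change is available, so the expectation rests on compound 2 alone. For compound 4 the step of a 1.4-fold higher number from compound 2 to compound 4 (0.15 log units; within the scatter) is expected to be small, probably upward but not clearly beyond the scatter. Compound 4 is therefore estimated at 80000 nM, with a range from 35000 nM to 180000 nM.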

Compound 4, solubility: 640000 nM
For compound 4 the middle estimate is 8.0-fold (0.90 log units) below the measured one; the measured number lies above the stated range.
By their numbers in this assay, from the lowest: compound 3; then compounds 1 and 2 (each within the scatter of the next); then compound 4.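

In this assay, the exchange of 4,4-dimethyl-2-oxopyrrolidin-1-yl for 2-oxopyrrolidin-1-yl on the aromatic carbon gives an 11-fold higher number from compound 2 to compound 4 (1.05 log units; beyond the scatter) and is the only step shown between compounds that differ in one place, since compound 1, compound 2 and compound 3 differ from one another in more than one place. It shows that this position is not indifferent to a small edit: the group goes from 8 to 6 heavy atoms, while the five-membered ring, the double bond outside aromatic rings, the hydrogen-bond counts and the absence of net charge all stay the same. No measurement shown accounts for the size of this step.

The compounds shown leave open whether a single methyl on the lactam ring, a six-membered lactam, an open-chain amide or a morpholine at this place would stay near compound 4 or fall back towards compound 2. They also leave open whether the same exchange would give a step of similar size on a different core, as this single pair cannot show how far it carries.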